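The source may report more compounds than this note shows. Statements on the series, on what has been measured and on what is new or still open speak of the compounds shown alone.

Measured compounds:
compound 1, `NC(=S)NNc1nncc2ccccc12`, in a functional assay on SF-268 cells (Homo sapiens) for antiproliferative activity, read by sulforhodamine B assay, with a stated time of 72 h; on this read-out higher numbers stand for weaker inhibition and lower numbers for stronger inhibition: 17 nM
compound 2, `COc1ccc(NC(=S)NNc2nncc3ccccc23)cc1`: 86 nM
compound 3, `Cc1cc(C)nc(NS(=O)(=O)c2ccc(Nc3nncc4ccccc34)cc2)n1`: 7.6 nM

Of these three numbers, compound 3 has the lowest. Compound 1 stands nearest to it and compound 2 furthest, and both gaps lie beyond the scatter, so compound 3 is the most potent of the three. Compound 4, `O=S(=O)(Nc1ncccn1)c1ccc(Nc2nncc3ccccc23)cc1`, is compound 3 altered in one place: pyrimidin-2-yl in place of 4,6-dimethylpyrimidin-2-yl on a sulfonamide nitrogen. For the measured compounds named here, no step of this kind between measured compounds is available, so its size is uncertain. The change is confined to the group on the sulfonamide nitrogen, and the step of a 1.4-fold higher number from compound 3 to compound 4 (0.16 log units; within the scatter) is expected to stay within the scatter or be a slight weakening. Compound 4 is therefore expected to give about 11 nM in this assay. Compound 4 is estimated to fall between 3.5 nM and 35 nM.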

Compound 4, half-maximal inhibitory concentration: 34 nM
The estimate for compound 4 lay 3.1-fold (0.49 log units) below the measured number; low and high end bracket the measured number.
By their numbers in this assay, from the lowest: compound 3; then compounds 1 and 4 (each within the scatter of the next); then compound 2.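

With this assay, the group on the sulfonamide nitrogen proves not to be a silent position: pyrimidin-2-yl in place of 4,6-dimethylpyrimidin-2-yl gives a 4.5-fold higher number from compound 3 to compound 4 (0.65 log units; beyond the scatter). For the compounds shown here, this is the only comparison here between compounds differing in one place, and it shows that the methyl groups on that ring count for potency, with the dimethyl compound the stronger. Nothing available explains this step.

Going by these compounds, it remains open how a phenyl, a pyridin-2-yl or an acetyl group on that nitrogen would read in this assay. On these data alone, it also remains open whether this change would shift other compounds by a similar amount.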